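Amide substituent variation on the shared core

The source may report more compounds than this note shows. Statements on the series, on what has been measured and on what is new or still open speak of the compounds shown alone.

Among the measured compounds shown here, compound 2 `CCOC(=O)CN(C)C(=O)c1ccc(C(CC)(CC)c2ccc(OCCC(O)(CC)CC)c(C)c2)n1CC` gives the only number in a functional assay on Caco-2 cells (Homo sapiens) for antiproliferative activity, read by MTT assay, with a stated time of 48 h (a higher number here means a weaker inhibitor, a lower number a stronger inhibitor), so far: in that assay compound 2 gives 30300 nM. Compound 1 `CCn1c(C(=O)NCC#N)ccc1C(CC)(CC)c1ccc(OCCC(O)(CC)CC)c(C)c1` reaches only a limit of the assay in this assay, > 50000 nM. For the measured compounds named here, the single measured step, an at least 1.6-fold lower number from compound 1 to compound 2 (0.21 log units; that floor lies within the scatter), is the sole guide here, and it rests on (the limit of > 50000 nM in this assay, at which 1 of the 2 values shown sits). Compound 3 `CCn1c(C(=O)NC(C)CO)ccc1C(CC)(CC)c1ccc(OCCC(O)(CC)CC)c(C)c1` carries (1-(hydroxymethyl)ethyl)amino in place of ((ethoxycarbonyl)methyl)(methyl)amino on a carbonyl carbon, a change at the same carbonyl carbon as the measured step. A step within the scatter is expected from this change, a 1.2-fold higher number from compound 2 to compound 3 (0.06 log units; within the scatter). Compound 3 is therefore estimated at 35000 nM, with a range of 12000 nM to 100000 nM.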

Compound 3, half-maximal inhibitory concentration: > 50000 nM
Compound 3: no number, only a limit (the forecaster's own chance of this, stated with the estimate: 40%); at least 1.4-fold (0.15 log units) between middle value and limit.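

In this assay compound 3 gives only a limit, not a number. On this carbonyl carbon, (1-(hydroxymethyl)ethyl)amino in place of ((ethoxycarbonyl)methyl)(methyl)amino gives an at least 1.6-fold higher number from compound 2 to compound 3 (0.21 log units; that floor lies within the scatter), so a secondary amide bearing a hydroxyl group also yields only a floor within the scatter, and no difference is established. The step between the two limit compounds cannot be read, and compound 2 remains the only one with a number: the limit of > 50000 nM in this assay, at which 2 of the 3 values shown sit.

Open, from the compounds shown here alone, is how a piperazine or a carboxylic acid on this carbonyl carbon would read in this assay, and whether any group here gives a step beyond the scatter.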